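This account rests on a few compounds, and the source may have more. Where it says the series, first, only, none or still open, it means among the compounds named here.

Measured so far in a functional assay on MIA PaCa-2 cells (Homo sapiens) for inhibition, read by MTT assay, with a stated time of 7 days; on this read-out lower numbers stand for stronger inhibition and higher numbers for weaker inhibition:
compound 1 `CCC(CC)S(=O)(=O)c1ccc(S(=O)(=O)N2CCC[C@@H](C(=O)N3CCC(F)(F)CC3)C2)cc1`: 13 nM
compound 2 `CCN(CC)S(=O)(=O)c1ccc(S(=O)(=O)N2CCC[C@@H](C(=O)N3CCOCC3)C2)cc1`: 350 nM

Compound 2 has the higher of these two numbers (350 nM) and so is the weaker inhibitor. The gap down to compound 1 (13 nM) lies beyond the scatter of repeated measurements. These two compounds differ in more than one place, so their gap cannot be tied to any single group.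

The next compound, compound 3 `CCN(CC)S(=O)(=O)c1ccc(S(=O)(=O)N2CCC[C@@H](C(=O)N[C@@H]3CCOC3)C2)cc1`, keeps the core of compound 2 and changes one group on a carbonyl carbon. There, (oxolan-3-yl)amino stands in place of morpholin-4-yl ((oxolan-3-yl)amino in place of morpholin-4-yl on a carbonyl carbon). The two compounds have the same atoms, joined differently.

Within the data shown here, no measured pair shows what this kind of swap does in this assay, so the expectation starts from compound 2 (350 nM) and leans only slightly towards weaker inhibition. The expected change, a 1.1-fold higher number from compound 2 to compound 3 (0.06 log units; within the scatter), is no step beyond the scatter, although the missing precedent leaves either direction open. The estimate for compound 3 is 400 nM, with an expected range from 80 nM to 2000 nM.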

Compound 3, half-maximal inhibitory concentration: 750 nM
Compound 3: middle estimate off by 1.9-fold (0.27 log units), on the low side; the range from low to high includes it.
By their numbers in this assay, from the lowest: compound 1; then compound 2; then compound 3.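

In this assay, among these compounds, this is the first comparison that differs in only one place, and it shows that the group on this carbonyl carbon can affect inhibition. Replacing morpholin-4-yl with (oxolan-3-yl)amino gives a 2.1-fold higher number from compound 2 to compound 3 (0.33 log units; beyond the scatter), a modest weakening even though the atoms themselves stay the same and only their arrangement differs. The change alters several things at once, turning a six-membered ring into a five-membered one and adding both a hydrogen-bond donor and a defined stereocentre, and no measurement shown here indicates which of these matters.

The compounds shown leave open whether ring size, the amide hydrogen or the stereocentre accounts for the step, and an (oxan-4-yl)amino group, which has a six-membered ring and an amide hydrogen, would help to separate the first two. They also leave open how the mirror-image form of the (oxolan-3-yl)amino group would compare, which bears directly on whether the stereocentre matters at this position.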